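The compounds below may be only part of what the source reports. "The series", "measured", "known", "first", "only" and "open" are said of these compounds alone.

In a functional assay on HepG2 cells (Homo sapiens) for antiproliferative activity, read by MTT assay (a higher number here means a weaker inhibitor, a lower number a stronger inhibitor), compound 3 `COc1cc2ncnc(NCc3cccc(NC(=O)Nc4ccccc4C)c3)c2cc1OC` gives only a limit, > 50000 nM, and not a number. Compound 1 `COc1ccccc1NC(=O)Nc1cccc(CNc2ncnc3ccccc23)c1` gives 17500 nM, and compound 2 `O=C(Nc1ccc(F)cc1)Nc1cccc(CNc2ncnc3ccccc23)c1` gives 41500 nM. Compound 4 `COc1ccccc1NC(=O)Nc1cccc(CNc2ncnc3cc(OC)c(OC)cc23)c1` differs from compound 3 by methoxy in place of methyl on an aromatic carbon, so that 2-methylphenyl becomes 2-methoxyphenyl on the urea. Among the compounds with values here, the one measured step, a 2.4-fold higher number from compound 1 to compound 2 (0.38 log units; beyond the scatter), exchanges 2-methoxyphenyl for 4-fluorophenyl on the unsubstituted core, a different change, and so it does not speak to methyl against methoxy. Within the data shown here, no measured step bears directly on this change. The step of an at least 1.2-fold lower number from compound 3 to compound 4 (0.09 log units; that floor lies within the scatter) is therefore expected to be small, if present at all. Compound 4 is estimated at 40000 nM, within 12000 nM to 120000 nM in this assay.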

Compound 4, half-maximal inhibitory concentration: 27200 nM
Beside the measured number, compound 4's estimate is 1.5-fold (0.17 log units) above it, and the stated range covers the measured number.
By their numbers in this assay, from the lowest: compounds 1, 4 and 2 (each within the scatter of the next, the first and the last beyond it). At a limit, above all of these: compound 3.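

In this assay, 2-methoxyphenyl in place of 2-methylphenyl gives an at least 1.8-fold lower number from compound 3 to compound 4 (0.26 log units; that floor lies within the scatter). Only a floor can be read, because compound 3 sits at a limit of the assay: the limit of > 50000 nM in this assay, at which 1 of the 4 values shown sits. Within the data shown here, this is the first direct comparison of these two groups at this position, and it gives compound 4 a measured number, but with that floor inside the scatter, a real difference is not established.

Still open, going by these compounds, is how an amine or a chlorine atom would read at this place. On these data alone, it is also open whether methyl and methoxy would compare in the same way on the core of compound 1.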